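A Smaller Side Group on a Shared Core

The source may report more compounds than this note shows. Statements on the series, on what has been measured and on what is new or still open speak of the compounds shown alone.

Compound 1 `Cc1cc(C)c(CN2CCc3c(Cl)cc([C@@H](CO)[C@@H]4CCOC4)c(Cl)c3C2=O)c(=O)[nH]1` was tested in an assay for inhibition of histone-lysine N-methyltransferase EZH2 variant Y641N (Homo sapiens), read by scintillation counting, with a stated time of 60 min, in the presence of a further agent that is not named here (a higher number here means a weaker inhibitor, a lower number a stronger inhibitor), and gives 1260 nM. Of the two compounds with a single number here, compound 1 stands highest, so it is the weaker inhibitor of that pair. Compound 3 `COc1cc(C)[nH]c(=O)c1CN1CCc2c(Cl)cc([C@H](O)C3COC3)c(Cl)c2C1=O` in this assay gives 1.5 nM, a far lower number, and the gap between compound 1 and compound 3 lies beyond the scatter. Compound 2 `COC(c1cc(Cl)c2c(c1Cl)C(=O)N(Cc1c(C)cc(C)[nH]c1=O)CC2)C1CCN(C(C)=O)CC1` has more than one entry in this assay, 157 nM; 0.15 nM (2 entries), and the entries disagree with each other (the several entries of compound 2 in this assay, 157 nM; 0.15 nM (2 entries)), so no single number can be set for it.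

Compound 4 `Cc1cc(C)c(CN2CCc3c(Cl)cc([C@H](C)CO)c(Cl)c3C2=O)c(=O)[nH]1` has not yet been measured in this assay. It differs from compound 1 in one place: methyl in place of oxolan-3-yl on a saturated chain carbon bound to an aromatic carbon and a saturated chain carbon. Among the compounds with values here, no pair of measured compounds shares this same change, so there is no measured step to lean on. Swapping the oxolan-3-yl group for methyl is expected to make compound 4 a somewhat weaker inhibitor than compound 1, by a moderate step, though an outcome within the scatter cannot be ruled out. The estimated step is a 2.4-fold higher number from compound 1 to compound 4 (0.38 log units; beyond the scatter). In this assay compound 4 is expected to give about 3000 nM, with a likely range from 800 nM to 12000 nM.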

Compound 4, inhibition constant: 17 nM
The estimate for compound 4 lay 180-fold (2.25 log units) above the measured number, outside the stated range (below it).
By their numbers in this assay, from the lowest: compound 3; then compound 4; then compound 1.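

Swapping oxolan-3-yl for methyl on a saturated chain carbon bound to an aromatic carbon and a saturated chain carbon gives, in this assay, a 74-fold lower number from compound 1 to compound 4 (1.87 log units; beyond the scatter), a large step. At this place, then, a ring of 5 heavy atoms with a hydrogen-bond acceptor and a defined stereocentre is not needed for strong inhibition, and methyl, with 1 heavy atom and no ring, gives a much stronger inhibitor on the shared core. Nothing measured here bears on why the step is so large.

The compounds shown leave open how the number moves with other groups on this carbon, such as ethyl, a longer chain, an amine, or cyclopentyl, which would keep a five-membered ring without its oxygen, so this single step cannot say whether the ring itself or its oxygen accounts for the difference. As far as these compounds go, this change also appears only once, so it remains unknown whether the same swap would bring a step of similar size on any other compound.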